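Moving one fluorine: from compound 1 to compound 4

This account rests on a few compounds, and the source may have more. Where it says the series, first, only, none or still open, it means among the compounds named here.

In a functional assay on THP-1 cells (Homo sapiens) for cytotoxicity, read by MTT assay, with a stated time of 24 h (on this read-out lower numbers stand for stronger inhibition and higher numbers for weaker inhibition), compound 1 `COc1cc(/C=C2\CN(C)C/C(=C\c3ccccc3F)C2=O)cc(OC)c1` gives 1170 nM. Compound 2 `COc1cc(/C=C2\CN(C)C/C(=C\c3ccccc3F)C2=O)cc(OC)c1OC` gives 640 nM, and compound 3 `CN1C/C(=C\c2ccc(C(C)(C)C)cc2)C(=O)/C(=C/c2ccccc2F)C1` gives 13400 nM. Compound 1 therefore sits close to compound 2 and far below compound 3.

Compound 4 `COc1cc(/C=C2\CN(C)C/C(=C\c3ccc(F)cc3)C2=O)cc(OC)c1` has not yet been measured in this assay. It holds the same atoms as compound 1, joined differently: 4-fluorophenyl in place of 2-fluorophenyl on a double-bonded chain carbon bound to a double-bonded ring carbon. Put simply, 4-fluorophenyl stands in place of 2-fluorophenyl on a double-bonded chain carbon bound to a double-bonded ring carbon.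

Within the data shown here, no measured pair of compounds makes this kind of change. Among the measured compounds shown here, the only step available is a 1.8-fold lower number from compound 1 to compound 2 (0.26 log units; within the scatter), which puts methoxy in place of hydrogen on an aromatic carbon. That step stays within the scatter of repeated measurements, and it does not move a fluorine, so it gives only weak guidance. Nothing here argues for a shift beyond the scatter in either direction. The expected change is an estimated 1.0-fold higher number from compound 1 to compound 4 (0.01 log units; within the scatter). Compound 3, at 13400 nM, shows that numbers in this small family can lie far from that of compound 1, so the range is kept wide. Compound 4 is expected near 1200 nM, with an estimated range of 450 nM to 3200 nM.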

Compound 4, half-maximal inhibitory concentration: 5040 nM
Compound 4: the middle estimate sits 4.2-fold (0.62 log units) below what was measured; measured number outside the range, above it.
By their numbers in this assay, from the lowest: compounds 2 and 1 (each within the scatter of the next); then compound 4; then compound 3.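

In this assay, the step of a 4.3-fold higher number from compound 1 to compound 4 (0.63 log units; beyond the scatter) shows that this place responds to where the fluorine sits, even though the group that leaves and the group that enters have the same atoms and the same counts. Among these compounds, the only earlier step put a methoxy on the other aromatic group, left the 2-fluorophenyl untouched and stayed within the scatter, so the earlier compounds gave no sign that the group on this double-bonded chain carbon could shift the number beyond the scatter. Nothing at hand explains why 4-fluorophenyl gives the higher number, so this remains an observed difference in a single pair, with no measurement that accounts for it.

Going by these compounds, it stays open whether the same fluorine move would change the number in a similar way starting from compound 2 or compound 3. Also open, on these data alone, is how a plain phenyl or a 2-chlorophenyl on this double-bonded chain carbon would compare with 2-fluorophenyl, which would help show whether the fluorine itself matters here or only its place on the phenyl group.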